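Swapping Bromo for Trifluoromethyl Across Two Related Pairs

A few compounds are considered here, and "the series" means these few. Any claim that something is new, unique, unknown or untested is made for them only; others in the source may bear on it.

Of the compounds shown here, three sharing one core have been tested in a functional assay on K562 cells (Homo sapiens) for cytotoxicity, read by MTT assay, with a stated time of 24 h; a lower number here means a stronger inhibitor, a higher number a weaker inhibitor. Compound 1 `CN1C/C(=C\c2ccc(Br)cc2)C(=O)/C(=C/c2cccc([N+](=O)[O-])c2)C1` gives only a limit in this assay, namely > 20000 nM. Compound 2 `CN1C/C(=C\c2ccc(C(F)(F)F)cc2)C(=O)/C(=C/c2cccc([N+](=O)[O-])c2)C1` differs from compound 1 by trifluoromethyl in place of bromo on an aromatic carbon, a step of an at least 4.1-fold lower number from compound 1 to compound 2 (0.62 log units; beyond the scatter); in this assay compound 2 gives 4780 nM. Compound 3 `CN1C/C(=C\c2ccc(Br)cc2)C(=O)/C(=C/c2ccc(C#N)cc2)C1` gives 7420 nM in this assay; the difference between its core and the core of compound 1 is not broken down here, and the values of compound 2 and compound 3 sit within the scatter of each other. Compound 4 `CN1C/C(=C\c2ccc(C#N)cc2)C(=O)/C(=C/c2ccc(C(F)(F)F)cc2)C1` has not yet been measured. It differs from compound 3 by trifluoromethyl in place of bromo on an aromatic carbon, the same change as from compound 1 to compound 2, at the same place. The earlier step rests on a limit, (the limit of > 20000 nM in this assay, at which 1 of the 3 values shown sits), so its true size is known only as a lower bound. A lowering of comparable size is expected from compound 3, whose value is 7420 nM. The estimated step is a 3.0-fold lower number from compound 3 to compound 4 (0.47 log units; beyond the scatter). Compound 4 is therefore expected to give about 2500 nM in this assay, most likely between 800 nM and 8000 nM.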

Compound 4, half-maximal inhibitory concentration: 4010 nM
For compound 4 the middle estimate is 1.6-fold (0.21 log units) below the measured one; the range from low to high includes it.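

On the second core in this assay, trifluoromethyl in place of bromo gives a 1.9-fold lower number from compound 3 to compound 4 (0.27 log units; within the scatter), so this change does not clearly separate the two compounds there, whereas the step on the first core was printed as beyond the scatter. This does not show that the change acts differently on the two cores, since the two steps cannot be told apart: the same change on two cores in this assay, an at least 4.1-fold lower number (0.62 log units; beyond the scatter) from compound 1 to compound 2 and a 1.9-fold lower number (0.27 log units; within the scatter) from compound 3 to compound 4; the limit leaves it open whether they differ. Going by these compounds, compound 1 gives only a limit, so the full size of the first step remains unknown: the limit of > 20000 nM in this assay, at which 1 of the 4 values shown sits.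

With trifluoromethyl held in place, 4-cyanophenyl in place of 3-nitrophenyl gives a 1.2-fold lower number from compound 2 to compound 4 (0.08 log units; within the scatter), but this single pair says little about that side of the molecule in general. The compounds shown leave open whether an amine or a carboxylic acid in place of bromo or trifluoromethyl on the aromatic ring would move the value beyond the scatter, and whether the same change would carry over to further cores.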